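The source may report more compounds than this note shows. Statements on the series, on what has been measured and on what is new or still open speak of the compounds shown alone.

Compound 1 `Cn1nnnc1SCC(=O)N/N=C/c1ccccc1`: 3160000 nM
Compound 2 `Cn1nnnc1SCC(=O)N/N=C/c1ccc(Br)cc1`: > 10000000 nM
Compound 3 `CC(C)c1ccc(/C=N/NC(=O)CSc2nnnn2C)cc1`: 400000 nM

Three compounds built on the shared core of compound 1 have been examined in a functional assay on A549 cells (Homo sapiens) for cytotoxicity, read by XTT assay, with a stated time of 24 h; on this read-out higher numbers stand for weaker inhibition and lower numbers for stronger inhibition. Of the two plain numbers, compound 1 stands highest; the nearest number, from compound 3, lies a 7.9-fold lower number from compound 1 to compound 3 (0.90 log units; beyond the scatter). The value of compound 2 is a limit of the assay rather than a number (the limit of > 10000000 nM in this assay, at which 1 of the 3 values shown sits).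

Compound 4 `Cn1nnnc1SCC(=O)N/N=C/c1ccccc1O` is the next member. It differs from compound 1 by hydroxy in place of hydrogen on an aromatic carbon. Among the compounds with values here, two measured steps bear on this change, both putting a group on the same ring: an at least 3.1-fold higher number from compound 1 to compound 2 (0.50 log units; beyond the scatter), while a 7.9-fold lower number from compound 1 to compound 3 (0.90 log units; beyond the scatter). The two groups pulled in opposite directions, and neither is a hydroxy, so the sign of the present step is not settled by them. A hydroxy ortho to a large group is a smaller change than either of those, and a step no larger than the scatter, or a modest one in either direction, is therefore expected. The step expected is a 1.3-fold lower number from compound 1 to compound 4 (0.10 log units; within the scatter). In this assay compound 4 is estimated at 2500000 nM, within a range from 600000 nM to 9000000 nM.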

Compound 4, half-maximal inhibitory concentration: > 10000000 nM
Compound 4 ended at the assay's limit; the forecaster's own chance of this, stated with the estimate: 25%; middle value at least 4.0-fold (0.60 log units) from the limit.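

In this assay, hydroxy in place of hydrogen at this ring position, ortho to a large group, gives an at least 3.1-fold higher number from compound 1 to compound 4 (0.50 log units; beyond the scatter), so a group of a single heavy atom is enough to move the number beyond the scatter, towards weaker inhibition. Among the three ring changes now shown, hydroxy and bromo both go in this direction, while isopropyl in compound 3 goes against them and remains the only change that gives a lower number than compound 1. Compound 4 gives a limit and not a number, as compound 2 does, so the true size of the step stays unknown and the two compounds cannot be ordered: the limit of > 10000000 nM in this assay, at which 2 of the 4 values shown sit.

The compounds shown leave open whether this rise belongs to hydroxy itself or to its place on the ring, since no other group stands at this position and hydroxy stands at no other. A methoxy or an amine at the same position, or hydroxy elsewhere on the ring, would separate these two readings.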